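This account rests on a few compounds, and the source may have more. Where it says the series, first, only, none or still open, it means among the compounds named here.

Working notes on the series. Compound 1 `CN(C)C(=S)N/N=C/c1ccc2ccccc2n1` gives 30 nM in a functional assay on SGC-7901 cells (Homo sapiens) for antiproliferative activity, read by sulforhodamine B assay, with a stated time of 72 h; a higher number here means a weaker inhibitor, a lower number a stronger inhibitor. Compound 2 `COc1ccc(C)cc1NC(=S)N/N=C/c1ccc2ccccc2n1` is reported in this assay only as a limit, > 100000 nM, not as a number. Compound 3 `NC(=S)N/N=C/c1cc2cccnc2s1` gives 100000 nM in this assay. So compound 1 is the only member with a numerical reading well inside the range of this assay, while compound 2 sits at the limit of > 100000 nM in this assay, at which 1 of the 3 values shown sits, and compound 3 sits at the same concentration as a number.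

Compound 4 `Cc1cccc(NC(=S)N/N=C/c2ccc3ccccc3n2)c1` differs from compound 2 by hydrogen in place of methoxy on an aromatic carbon. Within the data shown here, no step between two measured compounds is available for this change, so its size cannot be read from measured pairs. Given that compound 2 gives no number at all, the expectation for compound 4 is no change beyond the scatter, with a good chance that this assay again reports only a limit. The estimated step of a number no higher from compound 2 to compound 4 (the limit leaves the size open) is therefore flat. Compound 4 is expected at 100000 nM, within 20000 nM to 300000 nM.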

Compound 4, half-maximal inhibitory concentration: > 100000 nM
Compound 4: only a limit was reported; the forecaster's own chance of this, stated with the estimate: 60%; the middle value sits exactly at the limit.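

Compound 2 and compound 4 are both reported only as limits in this assay, so no step can be read between them: the limit of > 100000 nM in this assay, at which 2 of the 4 values shown sit.

The compounds shown leave open what size of change, if any, hydrogen in place of methoxy on an aromatic carbon brings in this assay.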